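This account rests on a few compounds, and the source may have more. Where it says the series, first, only, none or still open, it means among the compounds named here.

Of the compounds shown here, three that share one core have been measured in an ADME assay on L929 cells (Mus musculus) for cytotoxicity, read by resazurin assay, with a stated time of 72 h; a lower number here means a stronger inhibitor, a higher number a weaker inhibitor. Compound 1 `O=C(O)c1ccc(C(=O)/C=C/c2ccc3c(c2)B(O)OC3)cc1` gives > 10 ug/mL in this assay, which is a limit of the assay and not a number. Compound 2 `Cc1ccc(C(=O)/C=C/c2ccc3c(c2)B(O)OC3)cc1` gives > 10 ug/mL in this assay, again only a limit. Compound 3 `CC(=O)Nc1ccc(C(=O)/C=C/c2ccc3c(c2)B(O)OC3)cc1` gives > 10 ug/mL in this assay, a limit as well. The common position of all three is the limit of > 10 ug/mL in this assay, at which 3 of the 3 values shown sit. The step that the two limits leave unreadable from compound 1 to compound 2 has no readable size, and the same holds for a step that the two limits leave unreadable from compound 1 to compound 3 and for a step that the two limits leave unreadable from compound 2 to compound 3. Compound 2 therefore stands only at a limit, with no number that would rank it against compound 1 or compound 3.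

The next compound, compound 4 `O=C(/C=C/c1ccc2c(c1)B(O)OC2)c1cccc(O)c1`, differs from compound 2 by 3-hydroxyphenyl in place of 4-methylphenyl on a carbonyl carbon. Each of the three measured steps alters the ring on the carbonyl carbon, which is the place changed here, and none of them moved the value off the limit. The expected step that the limit leaves unreadable from compound 2 to compound 4 is accordingly none beyond the scatter, and a limit rather than a number is expected as the most likely outcome. Compound 4 is estimated at 20 ug/mL in this assay, with a range from 8 ug/mL to 60 ug/mL.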

Compound 4, half-maximal inhibitory concentration: 7.56 ug/mL
Estimate against measurement, compound 4: 2.6-fold (0.42 log units) above; measured number outside the range, below it.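

In this assay compound 4 is the only one of the four compounds shown to give a number and not a limit, which shows that a change to the ring on the carbonyl carbon can bring the read-out off the limit. Putting 3-hydroxyphenyl in place of 4-methylphenyl is an at least 1.3-fold lower number from compound 2 to compound 4 (0.12 log units; that floor lies within the scatter), and this figure is only a floor, with the true size of the step left unknown and possibly larger. The steps among compounds 1, 2 and 3 cannot be read, so this is the only step in the set with any readable size, and most of the set still gives no number: the limit of > 10 ug/mL in this assay, at which 3 of the 4 values shown sit.

Whether the step belongs to the hydroxy group itself or to its place in 3-hydroxyphenyl stays open, as the compounds shown offer no second ring carrying that group to compare it with. Going by these compounds, how an amine or a methoxy group on that same ring would read in this assay also remains open, and so does whether any such group would carry the number further from the limit.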